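The source may hold more compounds than are shown below. What is called first, only, known or untested is meant among the compounds shown, and "the series" means these compounds.

Measured compounds:
compound 1 `COc1cccc([C@@H](CO)O[C@H]2CCCN(Cc3ccc(C(=O)O)cc3C)[C@H]2c2ccccc2)c1` — > 200000 nM
compound 2 `Cc1cc(C(=O)O)ccc1CN1CCC[C@H](O[C@H](CO)c2cc(Cl)cc(Cl)c2)[C@@H]1c1ccc(F)cc1` — "nd" (no result reported)

In an assay on isolated protein for activation of cGMP-dependent protein kinase 1 (Homo sapiens), read by ADP-Glo, with stated times of 30 min and 2 h (on this read-out higher numbers stand for an effect only at larger amounts of compound and lower numbers for an effect already at smaller amounts), compound 1 gives > 200000 nM, which is a limit of the assay rather than a number. Compound 1 therefore stands at the limit of > 200000 nM in this assay, at which 1 of the 2 values shown sits, with no single number beside it. For compound 2 no result is reported in this assay. Compound 3 `Cc1cc(C(=O)O)ccc1CN1CCC[C@H](O[C@H](CO)c2cc(F)cc(F)c2)[C@@H]1c1ccccc1` has not been measured yet. It differs from compound 1 by 3,5-difluorophenyl in place of 3-methoxyphenyl on a saturated chain carbon bound to an oxygen on a saturated carbon and a saturated chain carbon. Among the compounds with values here, with no measured step to draw on, the expected change from compound 1 to compound 3 is a number no higher from compound 1 to compound 3 (the limit leaves the size open), that is none beyond the scatter. Compound 3 is therefore estimated at 200000 nM, between 30000 nM and 400000 nM.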

Compound 3, half-maximal effective concentration: > 200000 nM
Compound 3 gave a limit, no number; the forecaster's own chance of this, stated with the estimate: 70%; the middle value lies on the limit itself.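

Compound 1 and compound 3 both end at a limit of the assay, so no step between them can be read: the limit of > 200000 nM in this assay, at which 2 of the 3 values shown sit.

As far as these compounds go, whether 3,5-difluorophenyl in place of 3-methoxyphenyl changes the read-out at all stays open.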